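A few compounds are considered here, and "the series" means these few. Any claim that something is new, unique, unknown or untested is made for them only; others in the source may bear on it.

Compound 1 `CC(C)(C)OC(=O)NCC1CCCN(C(=O)CN2CN(c3ccccc3)C3(CCN(C(=O)c4ccc(C5CCCCC5)cc4)CC3)C2=O)C1`: 3800 nM in an assay on HEK293 cells for displacement of a labelled ligand from NPC1-like intracellular cholesterol transporter 1 (Homo sapiens); a lower number here means a stronger inhibitor, a higher number a weaker inhibitor.
Compound 2 `CCC1CCCN(C(=O)CN2CN(c3ccccc3)C3(CCN(C(=O)c4ccc(C5CCCCC5)cc4)CC3)C2=O)C1`: 2600 nM in this assay.
Compound 3 `NC(=O)C1CCCN(C(=O)CN2CN(c3ccccc3)C3(CCN(C(=O)c4ccc(C5CCCCC5)cc4)CC3)C2=O)C1`: 3100 nM in this assay.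

Compound 3 sits between the other two, with a 1.2-fold higher number from compound 2 to compound 3 (0.08 log units; within the scatter) and, seen from the other side, a 1.2-fold lower number from compound 1 to compound 3 (0.09 log units; within the scatter); all three values lie within the usual scatter of one another, so none can be called stronger or weaker. Compound 4 `CC(C)(C)OC(=O)NC1CCCN(C(=O)CN2CN(c3ccccc3)C3(CCN(C(=O)c4ccc(C5CCCCC5)cc4)CC3)C2=O)C1` differs from compound 3 in one place: (tert-butoxycarbonyl)amino in place of carbamoyl on a saturated ring carbon. The measured steps that touch the same part of the shared core, a 1.5-fold lower number from compound 1 to compound 2 (0.16 log units; within the scatter) and a 1.2-fold lower number from compound 1 to compound 3 (0.09 log units; within the scatter), each moved the number by less than the scatter. The expected step is therefore a 1.1-fold higher number from compound 3 to compound 4 (0.03 log units; within the scatter) in this assay, which is none beyond the scatter. Compound 4 is expected to give 3300 nM, with a range from 1500 nM to 7000 nM.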

Compound 4, half-maximal inhibitory concentration: 4400 nM
For compound 4 the middle estimate is 1.3-fold (0.12 log units) below the measured one; low and high end bracket the measured number.
By their numbers in this assay, from the lowest: compounds 2, 3, 1 and 4 (each within the scatter of the next).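

At this saturated ring carbon, (tert-butoxycarbonyl)amino cannot be told apart from carbamoyl, with a 1.4-fold higher number from compound 3 to compound 4 (0.15 log units; within the scatter), or from ethyl, with a 1.7-fold higher number from compound 2 to compound 4 (0.23 log units; within the scatter). Setting it directly on the ring, in place of ((tert-butoxycarbonyl)amino)methyl, gives a 1.2-fold higher number from compound 1 to compound 4 (0.06 log units; within the scatter), so the length of this link also makes no measurable difference here. Nothing available explains why these different groups give such similar numbers.

On these data alone, whether an amine or a carboxylic acid on this carbon would move the number beyond the scatter remains open. So does whether this flat picture would hold with changes elsewhere on the shared core.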